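The source may report more compounds than this note shows. Statements on the series, on what has been measured and on what is new or still open speak of the compounds shown alone.

Compound 1 `COC(=O)c1c(-c2ccc([N+](=O)[O-])cc2)oc2ccccc2c1=O`: in a functional assay on A549 cells (Homo sapiens) for cytotoxicity, read by MTT assay, with a stated time of 6 days (on this read-out higher numbers stand for an effect only at larger amounts of compound and lower numbers for an effect already at smaller amounts), compound 1 gives > 25 ug/mL, a limit.
Compound 2 `COC(=O)c1c(-c2ccc(OCc3ccccc3)cc2)oc2ccccc2c1=O`: in this assay compound 2 gives > 25 ug/mL, a limit.

Compound 2 has no number on this read-out, only that limit, so its true position is open. The record so far holds only (the limit of > 25 ug/mL in this assay, at which 2 of the 2 values shown sit).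

Compound 3 `COC(=O)c1c(-c2ccc(OCc3ccccc3)cc2)oc2ccc(OC)cc2c1=O` keeps the structure of compound 2 except for one change: methoxy in place of hydrogen on an aromatic carbon, part of a fused or bridged system of two rings (methoxy in place of hydrogen on an aromatic carbon).

For the measured compounds named here, the single measured step, a step that the two limits leave unreadable from compound 1 to compound 2, concerns a different change and gives no size to carry over. Going by the values given here, no measured step therefore bears directly on this methoxy change, and no direction can be read from the data. The expectation is that compound 3 shows no step beyond the scatter and most likely stays at the limit in this assay. The expected size is a step that the limit leaves unreadable from compound 2 to compound 3. For compound 3 the estimate is 30 ug/mL, with an expected range of 12 ug/mL to 60 ug/mL.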

Compound 3, concentration for half-maximal effect: 22.1 ug/mL
Beside the measured number, compound 3's estimate is 1.4-fold (0.13 log units) above it; the range from low to high includes it.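

Methoxy in place of hydrogen on this aromatic carbon, para to a fused ring, gives the first actual number in the series in this assay: compound 3 gives 22.1 ug/mL. The change reads as an at least 1.1-fold lower number from compound 2 to compound 3 (0.05 log units; that floor lies within the scatter), so the data fix only a floor for this step, and its true size could be larger. A single substitution on this ring is thus enough to bring the read-out to a measurable value, while the other compounds shown remain limits: the limit of > 25 ug/mL in this assay, at which 2 of the 3 values shown sit.

Going by these compounds, the step between compound 1 and compound 2, benzyloxy in place of nitro, cannot be read, so it remains open whether methoxy at this carbon would also give a number with the nitro group in place of benzyloxy. On these data alone, it also remains open whether this result is particular to methoxy, and an ethoxy, hydroxy or amino group or a chlorine atom on the same carbon, with the rest of compound 3 unchanged, would show how far the read-out follows the group placed there.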